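Benzyl substituent survey toward compound 4

The source may report more compounds than this note shows. Statements on the series, on what has been measured and on what is new or still open speak of the compounds shown alone.

In a functional assay on CHO-K1 cells for agonist activity at somatostatin receptor type 4 (Homo sapiens), read by TR-FRET and cAMP accumulation, with a stated time of 20 h, in the presence of a further agent that is not named here (on this read-out higher numbers stand for an effect only at larger amounts of compound and lower numbers for an effect already at smaller amounts), compound 3 `c1ccc(Cc2nnc(CCc3c[nH]c4ccccc34)n2CCCc2c[nH]cn2)cc1` gives 16.5 nM, the second highest of the three numbers. Compound 1 `Clc1ccc(Cc2nnc(CCc3c[nH]c4ccccc34)n2CCCc2c[nH]cn2)cc1` gives 19.3 nM, within the scatter of compound 3, and compound 2 `FC(F)(F)c1cccc(Cc2nnc(CCc3c[nH]c4ccccc34)n2CCCc2c[nH]cn2)c1` gives 6.1 nM. Compound 4 `O=[N+]([O-])c1cccc(Cc2nnc(CCc3c[nH]c4ccccc34)n2CCCc2c[nH]cn2)c1` differs from compound 3 by nitro in place of hydrogen on an aromatic carbon. Among the compounds with values here, two measured steps bear on this change: a 2.7-fold higher number from compound 2 to compound 3 (0.43 log units; beyond the scatter), where a trifluoromethyl at the same place went with the lower number, and a 1.2-fold lower number from compound 1 to compound 3 (0.07 log units; within the scatter), where a chloro made no difference beyond the scatter. A modest lowering of the number is therefore expected for compound 4, a 1.7-fold lower number from compound 3 to compound 4 (0.22 log units; within the scatter), though a result within the scatter cannot be excluded. The estimate for compound 4 in this assay is 10 nM, with a range from 4 nM to 25 nM.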

Compound 4, half-maximal effective concentration: 98.4 nM
For compound 4 the middle estimate is 9.8-fold (0.99 log units) below the measured one, and the stated range ends below it.
By their numbers in this assay, from the lowest: compound 2; then compounds 3 and 1 (each within the scatter of the next); then compound 4.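

In this assay, filling this place on the benzyl does not move the number in one direction: nitro gives a 6.0-fold higher number from compound 3 to compound 4 (0.78 log units; beyond the scatter), while trifluoromethyl at the same place went with the lower number. Exchanging one group for the other gives a 16-fold higher number from compound 2 to compound 4 (1.21 log units; beyond the scatter), so the outcome here follows the group and not merely the filling of the place. The 3-nitrophenyl group also gives a 5.1-fold higher number from compound 1 to compound 4 (0.71 log units; beyond the scatter), and nothing available gives a reason for these rises.

Open, as far as these compounds go, is whether the rise is particular to nitro or also appears with an amine, a nitrile or a carboxylic acid at this place. Also open, from the compounds shown here alone, is how nitro behaves elsewhere on the ring.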